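The compounds below may be only part of what the source reports. "The series", "measured", "known", "first", "only" and "open" are said of these compounds alone.

Compound 1 `CCc1cc(-c2ccc(F)cc2)nn1Cc1ccc(C(=O)NO)cc1` gives 16700 nM in a functional assay on HepG2 cells (Homo sapiens) for antiproliferative activity, read by MTT assay, with a stated time of 96 h; a lower number here means a stronger inhibitor of growth, a higher number a weaker inhibitor of growth. Compound 2 `O=C(CCCCNC(=O)c1cc(-c2ccc(F)cc2)[nH]n1)NO` stands differently: in this assay compound 2 shows only a limit, > 100000 nM, and not a number, so its position sits at the edge of what this assay reports (the limit of > 100000 nM in this assay, at which 1 of the 2 values shown sits). Compound 3 `O=C(CCCCCCNC(=O)c1cc(-c2ccc(F)cc2)[nH]n1)NO` carries one change, (2-(hydroxycarbamoyl)ethyl in place of hydroxycarbamoyl on a saturated chain carbon, four bonds along the chain from an amide-type nitrogen). Going by the values given here, no measured step of this kind stands in the data, so the expected step from compound 2 to compound 3 in this assay, an at least 3.3-fold lower number from compound 2 to compound 3 (0.52 log units; beyond the scatter), rests on judgement alone and is expected to point toward stronger growth inhibition, beyond the scatter. For compound 3 the estimated value in this assay is 30000 nM, within 5000 nM to 150000 nM.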

Compound 3, concentration for 50% growth inhibition: 23200 nM
Beside the measured number, compound 3's estimate is 1.3-fold (0.11 log units) above it; measured number inside the range.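

Setting 2-(hydroxycarbamoyl)ethyl in place of hydroxycarbamoyl gives an at least 4.3-fold lower number from compound 2 to compound 3 (0.63 log units; beyond the scatter) and so moves the chain-linked pair off the edge of this assay to a readable number. Going by these compounds alone, this pair is the first sign that the length of the chain at this position changes the result. The full size of the step stays unknown because compound 2 carries only a limit: the limit of > 100000 nM in this assay, at which 1 of the 3 values shown sits.

On these data alone, whether a still longer chain ending in hydroxycarbamoyl would lower the number further remains open. So does whether an amine or a carboxylic acid at the chain end would retain any growth inhibition.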